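Replacing 4-fluorophenyl with 3-bromophenyl on the shared core

The compounds below may be only part of what the source reports. "The series", "measured", "known", "first", "only" and "open" are said of these compounds alone.

In an ADME assay on MT4 cells (Homo sapiens) for cytotoxicity (a higher number here means that more compound is tolerated, a lower number that less compound is tolerated), compound 3 `Fc1ccc(NC(=S)Nc2cccc(C(F)(F)F)c2)cc1` gives 31000 nM. Within the data shown here, this is the higher of the two exact numbers so far, as compound 1 `FC(F)(F)c1cccc(NC(=S)Nc2ccc(Cl)cc2)c1` gives 6800 nM. Compound 2 `CCNC(=S)Nc1cccc(C(F)(F)F)c1`, which carries ethyl, reads > 100000 nM, and this is a limit of the assay. Compound 4 `FC(F)(F)c1cccc(NC(=S)Nc2cccc(Br)c2)c1` has 3-bromophenyl in place of 4-fluorophenyl on an amide-type nitrogen. The closest guide is the exchange of chloro for fluoro, a 4.6-fold higher number from compound 1 to compound 3 (0.66 log units; beyond the scatter), a modest step. Replacing ethyl with an aromatic ring also matters, as an at least 3.2-fold lower number from compound 2 to compound 3 (0.50 log units; beyond the scatter) shows, but compound 4 keeps such a ring. Among the measured compounds shown here, no measured compound carries bromo, so this guide is indirect. A modest drop is therefore expected, a 3.9-fold lower number from compound 3 to compound 4 (0.59 log units; beyond the scatter). Compound 4 is estimated at 8000 nM, with an expected range of 2500 nM to 25000 nM.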

Compound 4, half-maximal cytotoxic concentration: 9200 nM
For compound 4 the middle estimate is 1.2-fold (0.06 log units) below the measured one, within the range that was stated.
By their numbers in this assay, from the lowest: compounds 1 and 4 (each within the scatter of the next); then compound 3. At a limit, above all of these: compound 2.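

In this assay, the two aromatic rings on this amide-type nitrogen are not interchangeable, even though they have the same heavy-atom count: 3-bromophenyl in place of 4-fluorophenyl gives a 3.4-fold lower number from compound 3 to compound 4 (0.53 log units; beyond the scatter). Set against 4-chlorophenyl, the same group gives a 1.4-fold higher number from compound 1 to compound 4 (0.13 log units; within the scatter), so these two groups cannot be told apart here. Exchanging ethyl for 3-bromophenyl gives an at least 10-fold lower number from compound 2 to compound 4 (1.03 log units; beyond the scatter), a step whose true size stays open because one end is a limit: the limit of > 100000 nM in this assay, at which 1 of the 4 values shown sits.

The compounds shown leave open whether the drop from 4-fluorophenyl follows the halogen or its place on the ring. They also leave open how a ring carrying an amine or a carboxylic acid, or a longer chain in place of ethyl, would read.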